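Amide substituent change from compound 3 to compound 4

The source may report more compounds than this note shows. Statements on the series, on what has been measured and on what is new or still open speak of the compounds shown alone.

Values in an ADME assay on microsomes from liver (Mus musculus, strain CD-1) for metabolic stability, read by LC-MS, tested at 2 uM (a higher number here means that the compound lasts longer, a lower number that the compound disappears faster), are as follows.
- compound 1 `Cn1cc(NC(=O)c2ccncc2Nc2cc(-c3ccc4ccn(C)c4c3)c3nccnc3c2)cn1` gives 0.2 h
- compound 2 `CN1CCC(NC(=O)c2ccncc2Nc2cc(-c3ccc4ccn(C)c4c3)c3nccnc3c2)CC1` gives > 1 h (a limit of the assay, not a number)
- compound 3 `CN1CCC(NC(=O)c2ccncc2Nc2cc(-c3ccc4ccn(C)c4c3)c3nccnc3c2)CC1=O` gives 0.717 h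

Among the measured compounds shown here, of the two exact numbers, the one for compound 3 is the higher (a 3.6-fold higher number from compound 1 to compound 3 (0.55 log units; beyond the scatter)). Its gap to the limit has a floor within the scatter (an at least 1.3-fold lower number from compound 2 to compound 3 (0.14 log units; that floor lies within the scatter)).

Compound 4 `Cn1ccc2ccc(-c3cc(Nc4cnccc4C(=O)NCC4COCCN4)cc4nccnc34)cc21` carries (morpholin-3-yl)methyl in place of 1-methyl-2-oxopiperidin-4-yl on an amide-type nitrogen and is still unmeasured.

Both measured exchanges of 1-methyl-1H-pyrazol-4-yl at this place went upward beyond the scatter (an at least 5.0-fold higher number from compound 1 to compound 2 (0.69 log units; beyond the scatter)) and (a 3.6-fold higher number from compound 1 to compound 3 (0.55 log units; beyond the scatter)). The new group also has a six-membered non-aromatic ring, so no change beyond the scatter is expected in this assay (a 1.0-fold lower number from compound 3 to compound 4 (0.01 log units; within the scatter)). Compound 4 is estimated at 0.7 h (0.3 h to 1.5 h).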

Compound 4, half-life: > 1 h
Compound 4 gave a limit, no number; the forecaster's own chance of this, stated with the estimate: 25%; middle value at least 1.4-fold (0.15 log units) from the limit.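

In this assay compound 4 gives > 1 h, a limit of the assay and not a number. This position therefore also tolerates (morpholin-3-yl)methyl, a ring with 2 hetero atoms, with an at least 5.0-fold higher number from compound 1 to compound 4 (0.69 log units; beyond the scatter), while an at least 1.3-fold higher number from compound 3 to compound 4 (0.14 log units; that floor lies within the scatter). The step between the two limits cannot be read, and no order can be given at the top of the series: the limit of > 1 h in this assay, at which 2 of the 4 values shown sit.

Still open, as far as these compounds go, is how far the values of compound 2 and compound 4 lie past the limit. Also open, from the compounds shown here alone, is how an open-chain amine or a carboxylic acid on the amide-type nitrogen would behave.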